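The compounds below may be only part of what the source reports. "The series", "measured", "known", "first", "only" and "open" are said of these compounds alone.

The study measures antiproliferative activity in a functional assay on NCI-H460 cells (Homo sapiens) for antiproliferative activity, read by MTT assay, with a stated time of 48 h; on this read-out lower numbers stand for stronger inhibition and higher numbers for weaker inhibition. Compound 1, with structure `CC1(C)Cc2c(ccc(C(=O)/C=C/c3ccc(Cl)cc3)c2OCc2ccccc2)O1`, is the simplest member. In this assay compound 1 gives only a limit, > 100000 nM, and not a number. Compound 2, with structure `CC1(C)Cc2c(ccc(C(=O)/C=C/c3cn(-c4ccccc4)nc3-c3cccc([N+](=O)[O-])c3)c2OCc2ccccc2)O1`, carries a larger substituted ring system on the enone side. In this assay compound 2 likewise gives only a limit, > 100000 nM, and not a number. Both values shown therefore sit at the same place, as the limit of > 100000 nM in this assay, at which 2 of the 2 values shown sit, records, so nothing about the direction or size of any step between them can be read from the data.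

Compound 3, with structure `CC1(C)Cc2c(ccc(C(=O)/C=C/c3cn(-c4ccccc4)nc3-c3ccc(Cl)cc3)c2OCc2ccccc2)O1`, has not yet been measured. It differs from compound 2 in a single place: 4-chlorophenyl in place of 3-nitrophenyl on an aromatic carbon. For the measured compounds named here, no measured step exists between two compounds that differ in this way, so the change must be judged from the two limits alone. Compound 3 is expected to show no step beyond the scatter, with a step that the limit leaves unreadable from compound 2 to compound 3 as the estimated shift from compound 2. Compound 3 is therefore estimated at 150000 nM in this assay, within a range from 50000 nM to 500000 nM, most probably reported again as a limit.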

Compound 3, half-maximal inhibitory concentration: > 100000 nM
Compound 3: no number, only a limit; the forecaster's own chance of this, stated with the estimate: 75%; the middle value does not contradict the limit.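

Compound 3 gives > 100000 nM in this assay as a limit and not a number. For the compounds shown here, no step from compound 2 to compound 3 can be read, since all the values shown sit at one place: the limit of > 100000 nM in this assay, at which 3 of the 3 values shown sit. The compounds shown leave open whether any change to the shared core gives a measurable value in this assay at all.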